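A few compounds are considered here, and "the series" means these few. Any claim that something is new, unique, unknown or untested is made for them only; others in the source may bear on it.

Measured so far:
compound 1 `COc1ccccc1-n1c(-c2coc3cc(C)c(Cl)cc3c2=O)nc(-c2ccccc2)c1-c1ccccc1` — 12500 nM
compound 2 `Cc1ccc(-n2c(-c3coc4cc(C)c(Cl)cc4c3=O)nc(-c3ccccc3)c2-c2ccccc2)c(C)c1` — 6250 nM

In a functional assay on A549 cells (Homo sapiens) for inhibition, read by MTT assay, with a stated time of 72 h (a higher number here means a weaker inhibitor, a lower number a stronger inhibitor), compound 1 gives 12500 nM and compound 2 gives 6250 nM. For the measured compounds named here, compound 2 holds the lowest of the two numbers, yet the only recorded step, a 2.0-fold lower number from compound 1 to compound 2 (0.30 log units; within the scatter), stays within the scatter, so the two compounds cannot be ordered. Compound 3 `COc1cccc(-n2c(-c3coc4cc(C)c(Cl)cc4c3=O)nc(-c3ccccc3)c2-c2ccccc2)c1` follows from compound 2 by the change (3-methoxyphenyl in place of 2,4-dimethylphenyl on an aromatic nitrogen). Going by the values given here, the one measured step that bears on it is a 2.0-fold lower number from compound 1 to compound 2 (0.30 log units; within the scatter): an exchange of the aryl group on the same aromatic nitrogen that produced nothing beyond the scatter. Compound 1, which carries a 2-methoxyphenyl on that nitrogen and gives 12500 nM in this assay, is the closer analogue of the group now entering. No step beyond the scatter is therefore expected, a 1.4-fold higher number from compound 2 to compound 3 (0.16 log units; within the scatter). Compound 3 is estimated at 9000 nM in this assay, within a range of 4000 nM to 20000 nM.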

Compound 3, half-maximal inhibitory concentration: 6250 nM
Compound 3: the middle estimate sits 1.4-fold (0.16 log units) above what was measured, and the stated range covers the measured number.
By their numbers in this assay, from the lowest: compounds 2, 3 and 1 (each within the scatter of the next).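

In this assay the exchange on the aromatic nitrogen gives no change at the digits printed from compound 2 to compound 3 (within the scatter) and so adds a second aryl exchange that stays within the scatter, this time with an oxygen-bearing group entering for 2,4-dimethylphenyl. For the compounds shown here, the comparison of the two methoxyphenyl groups gives a 2.0-fold lower number from compound 1 to compound 3 (0.30 log units; within the scatter) and is the first pair in which the groups differ only in where the methoxy sits on the phenyl ring, yet it resolves no difference either. Nothing available explains this flat reading at the position.

Compounds 1, 2 and 3 therefore leave the aryl groups on this nitrogen unordered. Still open, going by these compounds, is whether a carboxylic acid or an amine on this phenyl ring, or a longer alkyl chain in its place, would move the number beyond the scatter.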